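The compounds below may be only part of what the source reports. "The series", "measured", "known", "first", "only" and "open" are said of these compounds alone.

Compound 1 `N#Cc1ccc(/C=N/NC(=O)Nc2cc3c(Nc4ccc(F)c(Cl)c4)ncnc3cc2O[C@H]2CCOC2)cc1` gives 26400 nM in a functional assay on HepG2 cells (Homo sapiens) for cytotoxicity, read by MTT assay, with a stated time of 72 h; a higher number here means a weaker inhibitor, a lower number a stronger inhibitor.
Compound 2 `CC(C)(C)c1cc(/C=N/NC(=O)Nc2cc3c(Nc4ccc(F)c(Cl)c4)ncnc3cc2O[C@H]2CCOC2)cc(C(C)(C)C)c1O` gives 12500 nM in this assay.
Compound 3 `COc1cc2ncnc(Nc3ccc(F)c(Cl)c3)c2cc1NC(=O)N/N=C/c1ccc(C#N)cc1` gives 34100 nM in this assay.

Of the three, compound 2 has the lowest number, and its steps to compound 1 and compound 3 are both beyond the scatter. Compound 1 and compound 3 share a core and differ in one place, (methyl in place of oxolan-3-yl on an oxygen on an aromatic ring); this gave a 1.3-fold higher number from compound 1 to compound 3 (0.11 log units; within the scatter), a step that sits within the scatter. How the core of compound 2 differs from that of compound 1 is not broken down here.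

The unmeasured compound 4 `COc1cc2ncnc(Nc3ccc(F)c(Cl)c3)c2cc1NC(=O)N/N=C/c1cc(C(C)(C)C)c(O)c(C(C)(C)C)c1` is made from compound 2 by the same change, (methyl in place of oxolan-3-yl on an oxygen on an aromatic ring), at the same place. Because the earlier instance gave a 1.3-fold higher number from compound 1 to compound 3 (0.11 log units; within the scatter), the step is expected to be small again: the estimate is a 1.3-fold higher number from compound 2 to compound 4 (0.11 log units; within the scatter) in this assay. On that basis compound 4 is expected to give about 16000 nM in this assay, most likely between 7000 nM and 36000 nM, resting on a single prior instance of the change.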

Compound 4, half-maximal inhibitory concentration: 26800 nM
Compound 4: middle estimate off by 1.7-fold (0.22 log units), on the low side; measured number inside the range.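

In this assay, methyl in place of oxolan-3-yl on the oxygen gave a 2.1-fold higher number from compound 2 to compound 4 (0.33 log units; beyond the scatter), a modest step in the same direction as the earlier instance, and the two instances do not separate: the same change on two cores in this assay, a 1.3-fold higher number (0.11 log units; within the scatter) from compound 1 to compound 3 and a 2.1-fold higher number (0.33 log units; beyond the scatter) from compound 2 to compound 4, 1.7-fold (0.22 log units) apart, within the scatter of two such steps.
Across these two cores, then, the change can be carried over as a small shift towards a higher number, although one step lies within the scatter and the other just beyond it. Two pairs in one assay do not show that the step would hold on a further core, and they give no reason for its size.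

The compounds shown carry only oxolan-3-yl and methyl on this oxygen, so it remains open how a longer chain or a chain ending in an amine would behave there. As far as these compounds go, it is also open whether the step would stay the same with a carboxylic acid in place of the nitrile of compound 1.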